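The source may hold more compounds than are shown below. What is called first, only, known or untested is meant among the compounds shown, and "the series" means these compounds.

Measured compounds in an assay for inhibition of high affinity nerve growth factor receptor (Homo sapiens), read by HTRF, with a stated time of 30 min, in the presence of a further agent that is not named here; on this read-out lower numbers stand for stronger inhibition and higher numbers for weaker inhibition:
- compound 1 `Cc1cc(Nc2nc(NCc3ccc(F)cc3)nc3ccccc23)n[nH]1`: 20 nM
- compound 2 `Cc1ccc(CNc2nc(Nc3cc(C)[nH]n3)c3ccccc3n2)cc1`: 110 nM
- compound 3 `Cc1cc(Nc2nc(NCc3ccc(F)cc3F)nc3ccccc23)n[nH]1`: 200 nM

Compound 1 stands at the lowest of the three numbers in this assay. The nearest measured neighbour is reached by a 5.5-fold higher number from compound 1 to compound 2 (0.74 log units; beyond the scatter), the furthest by a 10-fold higher number from compound 1 to compound 3 (1.00 log units; beyond the scatter). Between the two weaker compounds the gap is a 1.8-fold higher number from compound 2 to compound 3 (0.26 log units; within the scatter), so they are not separated.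

Compound 4 `CCc1cc(Nc2nc(NCc3ccc(F)cc3)nc3ccccc23)n[nH]1` differs from compound 1 by methyl in place of hydrogen on a saturated chain carbon bound to an aromatic carbon. None of the three measured steps bears on this part of the structure: all of them concern the substituents on the benzylic aryl ring, and the 5-methyl-1H-pyrazol-3-yl group is the same in compounds 1, 2 and 3. The measured data therefore give no direct guide for the methyl to ethyl change, and the working expectation is a step within the scatter, with wider uncertainty than for a change that had a measured precedent.

For compound 4 the estimated value in this assay is 25 nM, with an expected range from 8 nM to 80 nM, which means an expected 1.3-fold higher number from compound 1 to compound 4 (0.10 log units; within the scatter).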

Compound 4, half-maximal inhibitory concentration: 53 nM
Estimate against measurement, compound 4: 2.1-fold (0.33 log units) below, and the stated range covers the measured number.
By their numbers in this assay, from the lowest: compound 1; then compound 4; then compounds 2 and 3 (each within the scatter of the next).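

In this assay, going by these compounds alone, the change from 5-methyl-1H-pyrazol-3-yl to 5-ethyl-1H-pyrazol-3-yl gives a 2.7-fold higher number from compound 1 to compound 4 (0.42 log units; beyond the scatter), the only measured step at this part of the structure. It shows that this position is not indifferent to one added methyl: the step is modest, but it goes towards weaker inhibition, so in this single pair the methyl group is favoured over the ethyl group. Nothing at hand speaks to why the number moves.

Going by these compounds, whether a propyl, isopropyl or cyclopropyl group, or hydrogen in place of the methyl, would shift the number further remains open, since one step sets no trend. Also open, on these data alone, is whether the same change would give a similar step in the 4-methylphenyl and 2,4-difluorophenyl compounds.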